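The source may hold more compounds than are shown below. What is called first, only, known or untested is meant among the compounds shown, and "the series" means these compounds.

Three compounds built on a shared core were tested in an ADME assay on J774 cells (Mus musculus) for cytotoxicity, read by MTT assay, with a stated time of 48 h, tested at 50 ug/mL; a higher number here means a weaker effect of the compound at the concentration tested, a lower number a stronger effect. Compound 1 `O=C(N/N=C/c1cccc(O)c1)c1cnccn1` gives 100%. Compound 2 `O=C(N/N=C/c1ccc(O)cc1)c1cnccn1` gives 100% in this assay; the difference between the core of compound 1 and the core of compound 2 is not broken down here, the two having the same atoms joined differently. Compound 3 `N#Cc1cccc(/C=N/NC(=O)c2cnccn2)c1` gives 100% in this assay. From compound 1 to compound 3 the change is cyano in place of hydroxy on an aromatic carbon, and the step of no change at the digits printed from compound 1 to compound 3 (within the scatter) is flat. Compound 4 `N#Cc1ccc(/C=N/NC(=O)c2cnccn2)cc1` has not yet been measured. It differs from compound 2 by cyano in place of hydroxy on an aromatic carbon, the same kind of change as from compound 1 to compound 3, except that here the cyano sits para to a large group rather than meta to a large group. Because no change at the digits printed from compound 1 to compound 3 (within the scatter) shows no shift, and because compound 2 already gives 100%, the step of no change at the digits printed from compound 2 to compound 4 (within the scatter) is expected to be equally flat. Compound 4 is therefore estimated at 100%, with a range expected from 88% to 100%.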

Compound 4, a percentage reported as activity, at one concentration (the size of the read-out at that concentration, not a potency): 100%
Beside the measured number, compound 4's estimate shows no gap at the digits printed; low and high end bracket the measured number.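

In this assay, cyano in place of hydroxy on an aromatic carbon, here para to a large group, gives no change at the digits printed from compound 2 to compound 4 (within the scatter), and this matches the step seen on the other core: the same change on two cores in this assay, no change at the digits printed (within the scatter) from compound 1 to compound 3 and no change at the digits printed (within the scatter) from compound 2 to compound 4, 0 percentage points apart, within the scatter of two such steps On these two cores, then, the change carries over unaltered in this read-out, and no listed compound goes against that. This does not show that the change is without effect in general, since the read-out is the size of the effect at a single concentration and not a potency, and all four compounds stand level, so the agreement is between two flat steps rather than two shifts of matching size.

The compounds shown leave open whether an amine or a carboxylic acid on the same aromatic carbon would read any differently from hydroxy and cyano. They also leave open whether a longer chain there would stay level with them, and whether the flat step would hold on a core other than these two.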